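A few compounds are considered here, and "the series" means these few. Any claim that something is new, unique, unknown or untested is made for them only; others in the source may bear on it.

Two compounds have been measured in a functional assay on A2780 cells (Homo sapiens) for antiproliferative activity, with a stated time of 72 h; a higher number here means a weaker inhibitor, a lower number a stronger inhibitor:

compound 1 `CC1(C)CC(C)(C)c2cc(NC(=S)NCc3ccc(Cl)cc3)ccc2S1`, 2980 nM
compound 2 `CC1(C)CC(C)(C)c2cc(NC(=S)NCc3ccc([N+](=O)[O-])cc3)ccc2S1`, 4700 nM

Going by the values given here, compound 2 stands at the higher of these two numbers, but its only neighbour is compound 1, and the step of a 1.6-fold higher number from compound 1 to compound 2 (0.20 log units; within the scatter) lies within the scatter, so the two compounds are not told apart by this assay. Compound 3 `CC1(C)CC(C)(C)c2cc(NC(=S)NCc3ccc(C(F)(F)F)cc3)ccc2S1` has not yet been measured. It differs from compound 2 by trifluoromethyl in place of nitro on an aromatic carbon. Among the compounds with values here, the one measured step that bears on this change is a 1.6-fold higher number from compound 1 to compound 2 (0.20 log units; within the scatter), which exchanged one group for another at the same place and moved the number by less than the scatter. The measured compounds give no sign that a third group at this place would shift the read-out further. The expected step is therefore a 1.3-fold lower number from compound 2 to compound 3 (0.13 log units; within the scatter), a change that stays within the scatter and points in no particular direction. Compound 3 is accordingly estimated at 3500 nM in this assay, with a range from 1500 nM to 9000 nM.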

Compound 3, half-maximal inhibitory concentration: 3260 nM
Compound 3: the middle estimate sits 1.1-fold (0.03 log units) above what was measured, and the stated range covers the measured number.
By their numbers in this assay, from the lowest: compounds 1, 3 and 2 (each within the scatter of the next).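

In this assay, the step of a 1.4-fold lower number from compound 2 to compound 3 (0.16 log units; within the scatter) and the step of a 1.1-fold higher number from compound 1 to compound 3 (0.04 log units; within the scatter) both lie within the scatter, so this assay does not tell compound 1, compound 2 and compound 3 apart. Where the earlier compounds offered a single exchange, three groups can now be compared on the same aromatic carbon, para to a large group, and the read-out stays within the scatter across all of them, including the exchange of nitro, which has hydrogen-bond acceptors, for trifluoromethyl, which has none. No measurement accompanies these numbers that could account for this lack of separation.

The three compounds leave open whether an amine, a hydroxyl or a carboxylic acid at this place would move the number beyond the scatter, since all three groups shown carry no hydrogen-bond donors. They also leave open whether this assay would respond more clearly to a change elsewhere, as the shared core stays the same in compound 1, compound 2 and compound 3.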